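Working notes on the amine aryl substituent step

A few compounds are considered here, and "the series" means these few. Any claim that something is new, unique, unknown or untested is made for them only; others in the source may bear on it.

Compound 2 `C=C(c1cccc2ccccc12)C1CCC2(CC1)COC(Nc1ccc(OC)cc1)OO2` stands lowest of the two numbers in a physicochemical assay for lipophilicity (a lower number here means a more polar compound, a higher number a more lipophilic compound), giving 5.46. Compound 1 `C=C(c1cccc2ccccc12)C1CCC2(CC1)COC(Nc1cc(Cl)cc(Cl)c1)OO2` gives 6.71; the step of a number 1.25 log units lower from compound 1 to compound 2 (beyond the scatter) came with 4-methoxyphenyl in place of 3,5-dichlorophenyl on an amine nitrogen. Compound 3 `C=C(c1cccc2ccccc12)C1CCC2(CC1)COC(Nc1ccc(C(F)(F)F)cc1)OO2` carries trifluoromethyl in place of methoxy on an aromatic carbon. Going by the values given here, no measured step covers this exact change; the only one bearing on it is a number 1.25 log units lower from compound 1 to compound 2 (beyond the scatter), which shows that a change of the group on the amine nitrogen moves this assay well beyond the scatter. For compound 3 a rise beyond the scatter is expected, a number 0.89 log units higher from compound 2 to compound 3 (beyond the scatter). Compound 3 is therefore estimated at 6.35, between 5.9 and 6.8.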

Compound 3, partition coefficient: 6.51
Compound 3: the middle estimate sits 0.16 log units below what was measured, and the stated range covers the measured number.
By their numbers in this assay, from the lowest: compound 2; then compounds 3 and 1 (each within the scatter of the next).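

Trifluoromethyl in place of methoxy on the aromatic carbon gives a number 1.05 log units higher from compound 2 to compound 3 (beyond the scatter) in this assay, so changing this single group, with the phenyl ring kept, moves the read-out beyond the scatter. Replacing 3,5-dichlorophenyl with 4-(trifluoromethyl)phenyl gives a number 0.20 log units lower from compound 1 to compound 3 (within the scatter), so these two aryl groups are not separated here. No available evidence bears on the reason for either step. Still open, on these data alone, is where a carboxylic acid or an amine on the same aromatic carbon would fall relative to compound 2 and compound 3.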